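A few compounds are considered here, and "the series" means these few. Any claim that something is new, unique, unknown or untested is made for them only; others in the source may bear on it.

Measured compounds:
- compound 1, `CC(C)=CCC1Cc2c(OCCCNC(=O)c3ccco3)cc(=O)n(CCCO)c2CC1(C)C`: in a functional assay on PANC-1 cells (Homo sapiens) for inhibition, read by MTT assay, with a stated time of 24 h, tested at 10 uM (on this read-out lower numbers stand for less inhibition and higher numbers for more inhibition at the one concentration tested (going by the name of the read-out)), compound 1 gives 4.3%
- compound 2, `CC(C)=CCC/C(C)=C/CC1Cc2c(OCCCNS(=O)(=O)c3ccc([N+](=O)[O-])cc3)cc(=O)n(CCCO)c2CC1(C)C`: in this assay compound 2 gives 0%

Going by the values given here, only these two values exist so far, and no pair differing in a single place has been measured. Compound 2 and compound 1 lie within the scatter of each other, so neither can be set above the other; both sit at the bottom of the range the read-out can report, with no inhibition to speak of at the concentration tested.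

Compound 3, `CC(C)=CCC/C(C)=C/CC1Cc2c(OCCCNC(=O)c3ccco3)cc(=O)n(CCCO)c2CC1(C)C`, has not been measured. It keeps the geranyl-type chain of compound 2 and differs from it in one place: (furan-2-yl)carbonyl in place of (4-nitrophenyl)sulfonyl on an amine nitrogen. The same (furan-2-yl)carbonyl is carried by compound 1, which also shows essentially no inhibition. Nothing in the two numbers suggests a step of any size beyond the scatter in this assay; the expected step from compound 2 to compound 3 is a number 4 percentage points higher from compound 2 to compound 3 (within the scatter). For compound 3 the estimate is 4%, in the range 0% to 15%.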

Compound 3, a percentage reported as inhibition, at one concentration (the size of the read-out at that concentration, not a potency): 2.8%
Beside the measured number, compound 3's estimate is 1.2 percentage points above it; the range from low to high includes it.
By their numbers in this assay, from the lowest: compounds 2, 3 and 1 (each within the scatter of the next).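

In this assay, (furan-2-yl)carbonyl in place of (4-nitrophenyl)sulfonyl on the amine nitrogen gives a number 2.8 percentage points higher from compound 2 to compound 3 (within the scatter) with the geranyl-type chain held fixed, so the two groups cannot be told apart at this position. The chain can now be compared directly and gives the same picture: 3-methylbut-2-en-1-yl in place of hydrogen on the saturated chain carbon bound to a double-bonded chain carbon gives a number 1.5 percentage points lower from compound 1 to compound 3 (within the scatter) with the (furan-2-yl)carbonyl held fixed. No supporting data on hand bear on these results.

Open, going by these compounds, is whether any group on that nitrogen, such as a benzoyl carrying a carboxylic acid or a primary amine, can move the number beyond the scatter in this assay at all. Equally open, on these data alone, is whether a longer chain than the geranyl-type chain would do so.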